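This account rests on a few compounds, and the source may have more. Where it says the series, first, only, none or still open, it means among the compounds named here.

Measured so far in an assay on microsomes from brain for inhibition of heme oxygenase 2 (Rattus norvegicus), using NADPH, with stated times of 10 min and 15 min; on this read-out higher numbers stand for weaker inhibition and lower numbers for stronger inhibition:
compound 1, `c1ccc(Cn2c(CC3CC4CCC3C4)nc3ccccc32)cc1`, 6300 nM
compound 2, `Brc1ccc(Cn2c(CC3CC4CCC3C4)nc3ccccc32)cc1`, 5100 nM

Compound 2 carries a bromo in place of the hydrogen of compound 1 on an aromatic carbon, and the two cannot be told apart in this assay: a 1.2-fold lower number from compound 1 to compound 2 (0.09 log units; within the scatter). Compound 2 is thus one of two compounds that stand together at the same level.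

Compound 3, `Brc1ccc(Cn2c(CC3CCCCC3)nc3ccccc32)cc1`, differs from compound 2 elsewhere: a group of 6 heavy atoms (6 carbon; one six-membered non-aromatic ring of carbon only) in place of a group of 7 heavy atoms (7 carbon; 2 five-membered non-aromatic rings of carbon only), on a saturated chain carbon bound to an aromatic carbon. Going by the values given here, no measured step touches this part of the molecule; the only step recorded, the one from compound 1 to compound 2, concerns the aromatic ring and lies within the scatter, so it gives no direction for a change on the saturated chain carbon. The expectation therefore rests on compound 2 alone, and the estimated step of a 1.6-fold higher number from compound 2 to compound 3 (0.20 log units; within the scatter) is given with a wide range. Compound 3 is expected to give about 8000 nM in this assay, between 2500 nM and 25000 nM.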

Compound 3, half-maximal inhibitory concentration: 5400 nM
The estimate for compound 3 lay 1.5-fold (0.17 log units) above the measured number; the range from low to high includes it.
By their numbers in this assay, from the lowest: compounds 2, 3 and 1 (each within the scatter of the next).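

In this assay, going by these compounds alone, the saturated chain carbon bound to an aromatic carbon is varied for the first time, and exchanging the group with 2 five-membered non-aromatic rings for cyclohexyl leaves the read-out within the scatter, with a 1.1-fold higher number from compound 2 to compound 3 (0.02 log units; within the scatter). The two carbon-only ring groups therefore cannot be told apart at this position, just as hydrogen and bromo could not be told apart on the aromatic carbon in a 1.2-fold lower number from compound 1 to compound 2 (0.09 log units; within the scatter). No independent evidence bears on this result.

Both groups have no hydrogen-bond donors or acceptors, so the compounds shown leave open whether an amine or a carboxylic acid at this position would shift the number beyond the scatter. Going by these compounds, it also remains open whether a phenyl ring or a longer chain there would separate from compound 3 at all.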